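The source may hold more compounds than are shown below. What is called first, only, known or untested is meant among the compounds shown, and "the series" means these compounds.

Working notes on the series. In a functional assay on DLA cells (Mus musculus) for cytotoxicity, read by LDH release, with a stated time of 48 h (a higher number here means a weaker inhibitor, a lower number a stronger inhibitor), compound 1 `Cc1ccc(C(=O)c2ccc(OCC(=O)Nc3nc(-c4ccccc4)cs3)c(C)c2)cc1` gives 27100 nM. Compound 2 `Cc1cc(C(=O)c2cccc(Br)c2)ccc1OCC(=O)Nc1nc(-c2ccccc2)cs1` gives 23600 nM in this assay, and these two values lie within the scatter of each other, so neither compound can be ranked above the other.

The next structure is compound 3 `Cc1cc(C(=O)c2ccccc2C)ccc1OCC(=O)Nc1nc(-c2ccccc2)cs1`. The change is 2-methylphenyl in place of 3-bromophenyl on a carbonyl carbon.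

Within the data shown here, only one measured step bears on this change: a 1.1-fold lower number from compound 1 to compound 2 (0.06 log units; within the scatter). It also alters the group on the carbonyl carbon, and it stays within the scatter. Among the measured compounds shown here, no measured compound carries the 2-methylphenyl group, so the evidence is indirect and thin, and it gives no basis for a direction.

On the strength of that single small step, no shift beyond the scatter is expected in this assay. The expected step is a 1.1-fold higher number from compound 2 to compound 3 (0.03 log units; within the scatter). For compound 3 the estimated value is 25000 nM, with an expected range of 14000 nM to 44000 nM.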

Compound 3, half-maximal inhibitory concentration: 23700 nM
The estimate for compound 3 lay 1.1-fold (0.02 log units) above the measured number; measured number inside the range.
By their numbers in this assay, from the lowest: compounds 2, 3 and 1 (each within the scatter of the next).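

In this assay, the new compound gives a 1.0-fold higher number from compound 2 to compound 3 (0.00 log units; within the scatter) and a 1.1-fold lower number from compound 1 to compound 3 (0.06 log units; within the scatter), so with the earlier pair, all three groups on the carbonyl carbon, 4-methylphenyl, 3-bromophenyl and 2-methylphenyl, now lie within the scatter of one another. The earlier compounds shown here offered a single swap at this place; compound 3 adds a second and a third comparison, and neither exchanging 3-bromophenyl for the carbon-only 2-methylphenyl nor exchanging 4-methylphenyl for 2-methylphenyl separates the compounds in this assay, although this holds only for these three groups. No supporting measurement accompanies these values that could account for this flat result.

As far as these compounds go, it remains open whether any group at this place can move the number beyond the scatter, for instance a phenyl ring carrying an amine or a carboxylic acid, or a longer chain in place of the ring. All three compounds also keep the rest of the shared core unchanged, so these values do not show whether a change elsewhere in the core would separate compounds in this assay.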